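The source may report more compounds than this note shows. Statements on the series, on what has been measured and on what is new or still open speak of the compounds shown alone.

Compound 1, `O=C(O)c1ccc(C(=O)/C(=C\c2ccc(Br)c([N+](=O)[O-])c2)SCc2ccccc2Cl)cc1`: 1000 nM in a functional assay on DU-145 cells (Homo sapiens) for inhibition, read by trypan blue exclusion, with a stated time of 96 h; on this read-out higher numbers stand for weaker inhibition of growth and lower numbers for stronger inhibition of growth.
Compound 2, `O=C(O)c1ccc(C(=O)/C(=C\c2ccc(Br)c([N+](=O)[O-])c2)SCc2ccc(Cl)cc2)cc1`: < 1000 nM in this assay, a limit of the assay rather than a number.
Compound 3, `O=C(O)c1ccc(C(=O)/C(=C\c2ccc(F)c([N+](=O)[O-])c2)SCc2ccc(Cl)cc2)cc1`: 50000 nM in this assay.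

Compound 3 carries the highest of the two numbers. From compound 2 to compound 1 the change is 2-chlorophenyl in place of 4-chlorophenyl on a saturated chain carbon bound to a sulfur, and the step is a number no lower from compound 2 to compound 1 (the limit leaves the size open). Going by these compounds, its size stays open because of the limit of < 1000 nM in this assay, at which 1 of the 3 values shown sits. Compound 4, `O=C(O)c1ccc(C(=O)/C(=C\c2ccc(F)c([N+](=O)[O-])c2)SCc2ccccc2Cl)cc1`, is not yet measured. It differs from compound 3 by 2-chlorophenyl in place of 4-chlorophenyl on a saturated chain carbon bound to a sulfur, the same change as from compound 2 to compound 1, made on a core that differs from that of compound 2 by fluoro in place of bromo on an aromatic carbon, a change whose step was an at least 50-fold higher number from compound 2 to compound 3 (1.69 log units; beyond the scatter). In this assay compound 4 is expected near 60000 nM, with a range from 20000 nM to 200000 nM. That expectation rests on a number no lower from compound 2 to compound 1 (the limit leaves the size open) and amounts to an expected 1.2-fold higher number from compound 3 to compound 4 (0.08 log units; within the scatter).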

Compound 4, concentration for 50% growth inhibition: 1000 nM
For compound 4 the middle estimate is 60-fold (1.78 log units) above the measured one, outside the stated range (below it).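

In this assay, 2-chlorophenyl in place of 4-chlorophenyl gives a 50-fold lower number from compound 3 to compound 4 (1.70 log units; beyond the scatter), and this change did not carry over unaltered from the core of compound 2 to the core of compound 3: the same change on two cores in this assay, a number no lower (the limit leaves the size open) from compound 2 to compound 1 and a 50-fold lower number (1.70 log units; beyond the scatter) from compound 3 to compound 4, at least 50-fold (1.69 log units) apart, beyond the scatter of two such steps. Fluoro in place of bromo with the 2-chlorobenzyl group present gives no change at the digits printed from compound 1 to compound 4 (within the scatter), so that change does not carry over unaltered either: the same change on two cores in this assay, an at least 50-fold higher number (1.69 log units; beyond the scatter) from compound 2 to compound 3 and no change at the digits printed (within the scatter) from compound 1 to compound 4, at least 50-fold (1.69 log units) apart, beyond the scatter of two such steps. Going by these compounds, the two pairs show that these changes depend on each other here, but not the full size of either gap, which stays open at one value: the limit of < 1000 nM in this assay, at which 1 of the 4 values shown sits.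

Whether the same holds with a chloro or a methoxy group in place of the bromo is left open. So is the outcome with an unsubstituted benzyl group on the sulfur, or with an ester or an amide in place of the carboxylic acid.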